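Changing the amide aryl group in a free fatty acid receptor series

A few compounds are considered here, and "the series" means these few. Any claim that something is new, unique, unknown or untested is made for them only; others in the source may bear on it.

Measured so far in a functional assay on CHO cells for agonist activity at Free fatty acid receptor 2 (Homo sapiens), read by cAMP accumulation; on this read-out higher numbers stand for larger maximal responses and lower numbers for smaller maximal responses:
- Compound 1 `CC(C)C(c1ccc(Cl)cc1)S(=O)(=O)Nc1nccs1`: < 30%, which is a limit of the assay rather than a number (the limit of < 30% in this assay, at which 1 of the 3 values shown sits).
- Compound 2 `CC(C)[C@H](C(=O)Nc1ccccn1)c1ccc(Cl)cc1`: 92%.
- Compound 3 `CC(C)[C@H](C(=O)Nc1nnc(C(F)(F)F)s1)c1ccc(Cl)cc1`: 115%.

Of the two compounds that give a number in this assay, compound 2 stands lowest; the nearest value, that of compound 3, lies higher by a gap beyond the usual scatter. Compound 1, the only sulfonamide of the set, reaches no number at all, while both amides reach large maximal responses.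

Compound 4 `CC(C)[C@H](C(=O)Nc1ncc[nH]1)c1ccc(Cl)cc1` has not yet been measured. It differs from compound 2 in one place: 1H-imidazol-2-yl in place of pyridin-2-yl on an amide-type nitrogen. Among the compounds with values here, no pair of measured compounds differs in a single place, so there is no measured step that maps directly onto this change. Within the data shown here, the two measured amides carry different aromatic groups on the amide nitrogen and both reach large maximal responses, which is the only guide at hand.

In this assay compound 4 is therefore expected to give about 85%, within a range from 40% to 115%. The step expected is a number 7 percentage points lower from compound 2 to compound 4 (within the scatter), a change that may well fall within the scatter, though with some chance that compound 4 reaches only a limit.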

Compound 4, largest response reached (reported as efficacy), in percent of the reference or control that the assay uses: 55%
For compound 4 the middle estimate is 30 percentage points above the measured one, within the range that was stated.
By their numbers in this assay, from the lowest: compound 4; then compound 2; then compound 3. At a limit, below all of these: compound 1.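

Within the data shown here, the change from pyridin-2-yl to 1H-imidazol-2-yl on the amide-type nitrogen gives the first step that can be read for a single change, and in this assay it is large: the step is a number 37 percentage points lower from compound 2 to compound 4 (beyond the scatter). So the maximal response at this position depends on which aromatic group is attached, which the earlier compounds, differing from one another in more than that group alone or with no step listed, did not show. Compound 4 still gives a number, and compound 1 alone remains at a limit of the assay: the limit of < 30% in this assay, at which 1 of the 4 values shown sits.

This one step changes ring size, the number of ring hetero atoms and the hydrogen-bond donor count together, so the compounds shown cannot say which of these differences goes with the lower response, and they offer no measured cause for it. On these data alone, a 1-methyl-1H-imidazol-2-yl group or a thiazol-2-yl group on the same amide nitrogen would bear on that question, and how either would behave remains open.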